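A ring in place of a chain: compound 3

A few compounds are considered here, and "the series" means these few. Any claim that something is new, unique, unknown or untested is made for them only; others in the source may bear on it.

Going by the values given here, in an ADME assay on microsomes from liver (Homo sapiens) for metabolic stability, read by LC-MS, tested at 1 uM (on this read-out higher numbers stand for fast clearance and lower numbers for slow clearance), compound 2 `CC(C)(O)CNCCCOc1ccc([C@H]2CC[C@]3(CC2)OOC2(O3)C3CC4CC(C3)CC2C4)cc1` gives 8 mL.min-1.g-1, the only actual number available. Compound 1 `N[C@H]1CC[C@H](Oc2ccc([C@H]3CC[C@]4(CC3)OOC3(O4)C4CC5CC(C4)CC3C5)cc2)CC1` gives < 7 mL.min-1.g-1, which is a limit of the assay and not a number. Compound 3 `CC(C)(O)CN1CCC(Oc2ccc([C@H]3CC[C@]4(CC3)OOC3(O4)C4CC5CC(C4)CC3C5)cc2)CC1` carries 1-(2-hydroxy-2-methylpropyl)piperidin-4-yl in place of 3-((2-hydroxy-2-methylpropyl)amino)propyl on an oxygen on an aromatic ring. Among the compounds with values here, only one measured step bears on this change, as it also exchanges the group on that oxygen. That step, an at least 1.1-fold higher number from compound 1 to compound 2 (0.05 log units; that floor lies within the scatter), has a floor within the scatter and shows no clear shift. No step beyond the scatter is therefore expected in this assay, in either direction. The expected step is a 1.1-fold higher number from compound 2 to compound 3 (0.05 log units; within the scatter). For compound 3 the estimated value is 9 mL.min-1.g-1, with an expected range from 5 mL.min-1.g-1 to 18 mL.min-1.g-1.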

Compound 3, intrinsic clearance in microsomes: 18 mL.min-1.g-1
Compound 3: middle estimate off by 2.0-fold (0.30 log units), on the low side; the range from low to high includes it.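

Replacing 3-((2-hydroxy-2-methylpropyl)amino)propyl with 1-(2-hydroxy-2-methylpropyl)piperidin-4-yl on the oxygen on an aromatic ring moves the read-out in this assay, with a 2.3-fold higher number from compound 2 to compound 3 (0.35 log units; beyond the scatter). Going by these compounds alone, this is the first step at this position that is clearly beyond the scatter, and it shows that clearance here responds to the group on that oxygen. Exchanging 4-aminocyclohexyl for the same piperidin-4-yl group gives an at least 2.5-fold higher number from compound 1 to compound 3 (0.41 log units; beyond the scatter), but that size is only a floor because compound 1 stands at a limit of the assay: the limit of < 7 mL.min-1.g-1 in this assay, at which 1 of the 3 values shown sits.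

The compounds shown do not separate the effect of closing the ring from that of the 2-hydroxy-2-methylpropyl group on the ring nitrogen. Going by these compounds, how an unsubstituted piperidin-4-yl or a morpholine at the end of the propyl chain would read remains open.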